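The compounds below may be only part of what the source reports. "The series", "measured", "known", "first", "only" and "open" are said of these compounds alone.

Measured so far:
Compound 1 `Cc1ccc(S(=O)(=O)N2C(=O)COC23C=CC(=O)C=C3)cc1`: 180 nM
Compound 2 `O=C1C=CC2(C=C1)OCC(=O)N2S(=O)(=O)c1ccc([N+](=O)[O-])cc1`: > 10000 nM (a limit of the assay, not a number)

For the measured compounds named here, in a functional assay on HeLa cells (Homo sapiens) for inhibition, read by sulforhodamine B assay, with a stated time of 74 h (a lower number here means a stronger inhibitor, a higher number a weaker inhibitor), compound 1 gives 180 nM, the only actual number so far. Compound 3 `O=C1C=CC2(C=C1)OCC(=O)N2S(=O)(=O)c1ccc(N2CCCC2=O)cc1` is next, with the change 2-oxopyrrolidin-1-yl in place of methyl on an aromatic carbon. Going by the values given here, one measured step bears on it, at the same place: nitro in place of methyl gives an at least 55-fold higher number from compound 1 to compound 2 (1.74 log units; beyond the scatter), a large step beyond the scatter. That step rests on (the limit of > 10000 nM in this assay, at which 1 of the 2 values shown sits). It is a single example with a different incoming group, so it sets the direction better than the size. A higher number is therefore expected in this assay, by a smaller step than that one. The estimated step is an 8.3-fold higher number from compound 1 to compound 3 (0.92 log units; beyond the scatter). For compound 3 the estimate is 1500 nM, with an expected range of 250 nM to 10000 nM.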

Compound 3, half-maximal inhibitory concentration: 880 nM
Estimate against measurement, compound 3: 1.7-fold (0.23 log units) above; the measured number falls inside the stated range.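

In this assay, the aromatic carbon para to a large group now has a replacement of methyl with a measured number: 2-oxopyrrolidin-1-yl, with 6 heavy atoms against 1, gives a 4.9-fold higher number from compound 1 to compound 3 (0.69 log units; beyond the scatter) and so keeps activity in the nanomolar range. The two incoming groups at this position do not behave alike, as 2-oxopyrrolidin-1-yl in place of nitro gives an at least 11-fold lower number from compound 2 to compound 3 (1.05 log units; beyond the scatter) and shows that the loss seen with nitro does not apply to every replacement of methyl. The size of that second step is only a bound, since compound 2 stands at a limit of the assay and not at a number: the limit of > 10000 nM in this assay, at which 1 of the 3 values shown sits.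

Going by these compounds, only methyl, nitro and 2-oxopyrrolidin-1-yl appear at this position, so where an amine, a methoxy group or a fluorine atom would fall stays open. An open-chain acetamido group would be needed to separate the five-membered ring from its carbonyl.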